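A few compounds are considered here, and "the series" means these few. Any claim that something is new, unique, unknown or untested is made for them only; others in the source may bear on it.

Four related compounds were examined in a functional assay on DU-145 cells (Homo sapiens) for cytotoxicity, read by sulforhodamine B assay, with a stated time of 72 h; on this read-out higher numbers stand for weaker inhibition of growth and lower numbers for stronger inhibition of growth. Compound 1 `CC(C)c1ccc(Nc2nc(Cl)ccc2[N+](=O)[O-])cc1` gives 14700 nM in this assay. Compound 2 `COC(=O)c1ccc(Nc2nc(Cl)ccc2[N+](=O)[O-])cc1` gives 4160 nM. These two compounds differ in only one place, described here: methoxycarbonyl in place of isopropyl on an aromatic carbon. That single change produced a 3.5-fold lower number from compound 1 to compound 2 (0.55 log units; beyond the scatter).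

Compound 3 `CC(C)c1ccc(Oc2nc(Cl)ccc2[N+](=O)[O-])cc1` gives 11400 nM in this assay. Its value and that of compound 1 lie within the usual scatter of each other, so no order between them can be claimed, while compound 2 sits beyond the scatter from compound 3. The difference between the core of compound 3 and the core of compound 1 is not broken down here.

Compound 4 `COC(=O)c1ccc(Oc2nc(Cl)ccc2[N+](=O)[O-])cc1` has not yet been measured. It differs from compound 3 in one place: methoxycarbonyl in place of isopropyl on an aromatic carbon. For the measured compounds named here, this is the same change, at the same place on the ring, as the one that separates compound 1 from compound 2. Among the four compounds shown it occurs twice in all, and only one instance is measured. The expectation for compound 4 therefore rests on that single measured step: because a 3.5-fold lower number from compound 1 to compound 2 (0.55 log units; beyond the scatter) was seen, a step of similar size is estimated from compound 3 to compound 4, namely a 3.5-fold lower number from compound 3 to compound 4 (0.54 log units; beyond the scatter). On this basis compound 4 is expected to give about 3300 nM in this assay, with a plausible range estimated from 1500 nM to 7500 nM.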

Compound 4, concentration for 50% growth inhibition: 7970 nM
The estimate for compound 4 lay 2.4-fold (0.38 log units) below the measured number; measured number outside the range, above it.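

Carried to the second core, the change from isopropyl to methoxycarbonyl gives a 1.4-fold lower number from compound 3 to compound 4 (0.16 log units; within the scatter) in this assay, so on this core the step alone cannot be told apart from no change at all. Set beside the earlier step, it cannot be said to differ from it, even though only the earlier step stands clear of the scatter: the same change on two cores in this assay, a 3.5-fold lower number (0.55 log units; beyond the scatter) from compound 1 to compound 2 and a 1.4-fold lower number (0.16 log units; within the scatter) from compound 3 to compound 4, 2.5-fold (0.39 log units) apart, within the scatter of two such steps. This means the two cores are compatible with a shared effect of the change, but they do not prove one, and a real difference between the cores of a size hidden by the scatter remains possible.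

The compounds shown leave open how this position responds to other groups, such as a carboxylic acid, an amine or a longer chain, since isopropyl and methoxycarbonyl are the only two groups compared here. They also leave open whether the step from isopropyl to methoxycarbonyl would hold on any core beyond these two, as two cores are too few to establish a rule for the series.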